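A few compounds are considered here, and "the series" means these few. Any claim that something is new, unique, unknown or untested is made for them only; others in the source may bear on it.

Measured so far in a functional assay on OVCAR-3 cells (Homo sapiens) for antiproliferative activity; on this read-out lower numbers stand for stronger inhibition of growth and higher numbers for weaker inhibition of growth:

Compound 1 `Cc1cc(C)c2c(O)cc(-c3cccc(F)c3)nc2n1` gives 18.2 nM.
Compound 2 `Cc1cc(C)c2c(O)cc(-c3cccc(Cl)c3)nc2n1` gives 170 nM.
Compound 3 `Cc1cnc2[nH]c(-c3cccc(Cl)c3)cc(=O)c2c1` gives 22.4 nM.

Compound 1 and compound 2 share one core and differ in a single place: fluoro in place of chloro on an aromatic carbon. That change produced a 9.3-fold lower number from compound 2 to compound 1 (0.97 log units; beyond the scatter). Compound 3 stands on a different core; the difference between the two cores of compound 3 and compound 2 is not broken down here. Compound 3 and compound 1 lie within the scatter of each other, while compound 3 and compound 2 are separated by a gap beyond the scatter.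

Compound 4 `Cc1cnc2[nH]c(-c3cccc(F)c3)cc(=O)c2c1` is not yet measured. It is related to compound 3 by the same change that relates compound 2 to compound 1: fluoro in place of chloro on an aromatic carbon. The place is the same in both pairs, so the change is of the same kind and on the same footing on the aryl ring, only on a different core.

For compound 4 the expectation rests on a single earlier instance, namely a 9.3-fold lower number from compound 2 to compound 1 (0.97 log units; beyond the scatter), carried over to a different core where the same change has not been tested. Within the data shown here, the step from compound 3 to compound 4 is therefore expected to go in the same direction but is estimated at a more cautious size, a 3.2-fold lower number from compound 3 to compound 4 (0.51 log units; beyond the scatter), because the earlier step of a 9.3-fold lower number from compound 2 to compound 1 (0.97 log units; beyond the scatter) is the only evidence and core context may alter its size. On that basis compound 4 is expected to give about 7 nM, with a likely range from 2.5 nM to 20 nM.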

Compound 4, concentration for 50% growth inhibition: 13.5 nM
For compound 4 the middle estimate is 1.9-fold (0.29 log units) below the measured one, within the range that was stated.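

In this assay, fluoro in place of chloro on an aromatic carbon gives a 1.7-fold lower number from compound 3 to compound 4 (0.22 log units; within the scatter), so on this core the exchange leaves the two compounds indistinguishable, and the clear effect seen on the core of compound 1 does not reappear at a readable size. The size of the step therefore does not carry from one core to the other in this series, and the core has to be counted as part of the context of the change: the same change on two cores in this assay, a 9.3-fold lower number (0.97 log units; beyond the scatter) from compound 2 to compound 1 and a 1.7-fold lower number (0.22 log units; within the scatter) from compound 3 to compound 4, 5.6-fold (0.75 log units) apart, beyond the scatter of two such steps. This does not show that the exchange is without effect on the core of compound 3, since a small step of the same direction could lie inside the scatter, and two pairs cannot show how the change would behave on any third core.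

The compounds shown leave open which of the places where the two cores differ governs the size of the step. Also open, from the compounds shown here alone, is how a methoxy group, a trifluoromethyl group or an amine on the same aromatic carbon would read on each core, and whether the two cores would again diverge for those groups.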